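Para-substituted styryl nitroimidazoles: macrophage tolerance notes

The source may hold more compounds than are shown below. What is called first, only, known or untested is meant among the compounds shown, and "the series" means these compounds.

Measured so far:
compound 1 `CC(O)Cn1c([N+](=O)[O-])cnc1/C=C/c1ccccc1` — 1500 nM
compound 2 `COc1cccc(/C=C/c2ncc([N+](=O)[O-])n2CC(C)O)c1` — 1300 nM

Compound 1 `CC(O)Cn1c([N+](=O)[O-])cnc1/C=C/c1ccccc1` gives 1500 nM in an ADME assay on cells (Macrophage, Homo sapiens) for cytotoxicity, read by MTT assay, with a stated time of 24 h (a higher number here means that more compound is tolerated, a lower number that less compound is tolerated), the higher of the two numbers shown. Its nearest neighbour is compound 2 `COc1cccc(/C=C/c2ncc([N+](=O)[O-])n2CC(C)O)c1`, which gives 1300 nM in this assay; the step of a 1.2-fold lower number from compound 1 to compound 2 (0.06 log units; within the scatter) is within the scatter, so the two are to be read as alike.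

Compound 3 `CC(O)Cn1c([N+](=O)[O-])cnc1/C=C/c1ccc(N(C)C)cc1` is not yet measured. It differs from compound 1 by dimethylamino in place of hydrogen on an aromatic carbon. Among the measured compounds shown here, the only measured step that bears on this change is the one from compound 1 to compound 2, a substituent in place of hydrogen on the same ring, and that step was within the scatter. On this basis no step beyond the scatter is expected for compound 3, and the step of a 1.1-fold lower number from compound 1 to compound 3 (0.03 log units; within the scatter) is estimated to stay small. Compound 3 is therefore expected to give about 1400 nM in this assay, with a range of 600 nM to 3500 nM.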

Compound 3, half-maximal cytotoxic concentration: 680 nM
Estimate against measurement, compound 3: 2.1-fold (0.31 log units) above; the range from low to high includes it.
By their numbers in this assay, from the lowest: compounds 3, 2 and 1 (each within the scatter of the next, the first and the last beyond it).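

In this assay, dimethylamino in place of hydrogen on an aromatic carbon, para to a large group, gives a 2.2-fold lower number from compound 1 to compound 3 (0.34 log units; beyond the scatter), so substitution at this place on the six-membered aromatic ring can lower the tolerated concentration, if only modestly. The methoxy step, a 1.2-fold lower number from compound 1 to compound 2 (0.06 log units; within the scatter), showed no such shift, and of the two steps shown, only the dimethylamino step lies beyond the scatter. No measurement shown accounts for this step.

As far as these compounds go, it remains open whether this step belongs to dimethylamino in particular or would also appear with a primary amine, a chlorine atom or a carboxylic acid at the same place. Also open, from the compounds shown here alone, is whether methoxy at this place would stay within the scatter of compound 1.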